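Amino removal on the shared core of compound 1

The source may hold more compounds than are shown below. What is called first, only, known or untested is meant among the compounds shown, and "the series" means these compounds.

compound 1 `COc1nc(N)nc2c1c(-c1cc3ccccc3o1)cn2[C@@H]1O[C@H](CO)[C@@H](O)[C@H]1O` — > 20000 nM
compound 2 `Cc1nc(N)c2c(-c3ccsc3)cn([C@@H]3O[C@H](CO)[C@@H](O)[C@H]3O)c2n1` — > 20000 nM

In a functional assay on HeLa S3 cells (Homo sapiens) for antiproliferative activity, read by XTT assay, with a stated time of 72 h (on this read-out lower numbers stand for stronger inhibition and higher numbers for weaker inhibition), compound 1 returns only a limit, > 20000 nM, not a number. Compound 2 likewise returns only a limit, > 20000 nM. Compound 1 therefore stands at the limit of > 20000 nM in this assay, at which 2 of the 2 values shown sit, and no ordering of the two is possible. Compound 3 `COc1ncnc2c1c(-c1cc3ccccc3o1)cn2[C@@H]1O[C@H](CO)[C@@H](O)[C@H]1O` differs from compound 1 by hydrogen in place of amino on an aromatic carbon. Among the compounds with values here, no step between measured compounds is available for this change. Starting from a compound without measurable activity, no step beyond the scatter is expected in either direction. Compound 3 is expected to return a limit again, estimated near 30000 nM, within 10000 nM to 100000 nM. The expected step that the limit leaves unreadable from compound 1 to compound 3 is accordingly negligible.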

Compound 3, half-maximal inhibitory concentration: 9240 nM
Beside the measured number, compound 3's estimate is 3.2-fold (0.51 log units) above it; measured number outside the range, below it.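

In this assay there is an at least 2.1-fold lower number from compound 1 to compound 3 (0.33 log units; beyond the scatter) with hydrogen in place of amino on the aromatic carbon between two ring nitrogen atoms, so a measurable number on the shared core does not require the amino group at this position. The step gives only a lower bound on the change, because compound 1 stands at a limit: the limit of > 20000 nM in this assay, at which 2 of the 3 values shown sit.

Going by these compounds, the full size of the step stays open. Also open, on these data alone, is whether a methyl group, a chlorine atom or a dimethylamino group at this position would keep a measurable number.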